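Acrylamide to acrylate on the pyridine-indole series

This account rests on a few compounds, and the source may have more. Where it says the series, first, only, none or still open, it means among the compounds named here.

Compound 1 `O=C(COc1ccncc1-c1ccc2ccccc2c1)N1CCOCC1` has no reported result: in an assay on a protein complex for inhibition of CDK8/Cyclin C (Homo sapiens), with a stated time of 1 h (a higher number here means a weaker inhibitor, a lower number a stronger inhibitor), compound 1 stands as "not determined" (no result reported). In this assay, for the measured compounds named here, compound 2 `CNC(=O)/C=C/c1ccncc1-c1ccc2cc[nH]c2c1` gives 18.6 nM, the only number on hand, so it stands alone with no comparison available. Compound 3 `CCOC(=O)/C=C/c1ccncc1-c1ccc2cc[nH]c2c1` carries ethoxy in place of methylamino on a carbonyl carbon. Going by the values given here, no measured step covers this exchange, so the expectation for compound 3 rests on compound 2 alone. The step from compound 2 to compound 3 is expected to be a moderate weakening, a 3.2-fold higher number from compound 2 to compound 3 (0.51 log units; beyond the scatter), beyond the usual scatter. Compound 3 is therefore estimated at 60 nM, with a plausible range from 15 nM to 250 nM.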

Compound 3, half-maximal inhibitory concentration: 12.1 nM
Compound 3: middle estimate off by 5.0-fold (0.70 log units), on the high side; measured number below the stated range.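

In this assay, ethoxy in place of methylamino on a carbonyl carbon gives a 1.5-fold lower number from compound 2 to compound 3 (0.19 log units; within the scatter) and so leaves compound 2 and compound 3 indistinguishable. At this position, the amide hydrogen of compound 2 is therefore not required to keep the read-out in this range, and an ester serves as well as the amide. Nothing on hand explains this result.

Still open, on these data alone, is how a carboxylic acid or a longer alkoxy chain on the same carbonyl carbon would read. Also open, as far as these compounds go, is whether a dimethylamino group, which likewise lacks the amide hydrogen, would match the ethoxy result.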